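A few compounds are considered here, and "the series" means these few. Any claim that something is new, unique, unknown or untested is made for them only; others in the source may bear on it.

Compound 1, `O=[N+]([O-])c1cc(CSc2nnc(-c3ccccc3)n2-c2ccc(Cl)c(Cl)c2)cc([N+](=O)[O-])c1`. In an ADME assay on HepG2 cells (Homo sapiens) for cytotoxicity, with a stated time of 48 h (a higher number here means a weaker inhibitor, a lower number a stronger inhibitor), compound 1 gives > 30000 nM, which is a limit of the assay rather than a number.
Compound 2, `O=[N+]([O-])c1cc(CSc2nnc(-c3ccccc3)n2Cc2ccccc2)cc([N+](=O)[O-])c1`. In this assay compound 2 gives > 30000 nM, again a limit.
Compound 3, `O=[N+]([O-])c1cc(CSc2nnc(-c3ccc(Cl)cc3)n2Cc2ccccc2)cc([N+](=O)[O-])c1`. In this assay compound 3 gives > 30000 nM, also a limit.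

Compound 3 therefore stands only at a limit, and the two other measured values sit at the same limit, a point summed up as the limit of > 30000 nM in this assay, at which 3 of the 3 values shown sit. Going by the values given here, no measured compound has given a number in this assay.

Compound 4, `O=[N+]([O-])c1cc(CSc2nnc(-c3ccc(Br)cc3)n2Cc2ccccc2)cc([N+](=O)[O-])c1`, differs from compound 3 by bromo in place of chloro on an aromatic carbon.

Two measured steps exist, each changing one place: a step that the two limits leave unreadable from compound 1 to compound 2 and a step that the two limits leave unreadable from compound 2 to compound 3. Neither can be read, since both ends sit at the limit, so they give no size and no direction for the change from compound 3 to compound 4.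

With three values at the limit and no readable step, compound 4 is expected to give 30000 nM in this assay, within a range of 12000 nM to 100000 nM. This estimate means a step of a number no higher from compound 3 to compound 4 (the limit leaves the size open), most likely reported again as a limit rather than as a number.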

Compound 4, half-maximal inhibitory concentration: > 30000 nM
Compound 4 ended at the assay's limit (the forecaster's own chance of this, stated with the estimate: 85%); the middle value lies on the limit itself.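

Compound 4 gives a limit rather than a number, so neither its step from compound 3 nor its step from compound 2 can be read in this assay. The compounds shown leave open whether any of these changes alters the result at all, as every value remains a limit: the limit of > 30000 nM in this assay, at which 4 of the 4 values shown sit.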